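This account rests on a few compounds, and the source may have more. Where it says the series, first, only, none or still open, it means among the compounds named here.

Measured in an assay on RBL-1 cells for inhibition of Polyunsaturated fatty acid 5-lipoxygenase (Rattus norvegicus); a higher number here means a weaker inhibitor, a lower number a stronger inhibitor:
compound 1 `CCc1cccc(N2CCNC(=O)N2)c1` gives 13000 nM
compound 2 `O=C1NCCN(c2cccc(F)c2)N1` gives 19000 nM
compound 3 `O=C1NCCN(c2cccc(O)c2)N1` gives 32000 nM

Compound 3 holds the highest of the three numbers. Its gap to compound 2 lies within the scatter (a 1.7-fold higher number from compound 2 to compound 3 (0.23 log units; within the scatter)), while the step from compound 1 is modest but beyond it (a 2.5-fold higher number from compound 1 to compound 3 (0.39 log units; beyond the scatter)). Compound 4 `O=C1NCCN(c2cccc(-c3ccsc3)c2)N1` differs from compound 3 by thiophen-3-yl in place of hydroxy on an aromatic carbon. Within the data shown here, the only measured steps at this position are the two just named; neither covers an aromatic ring there, so the size of the new step is uncertain. Because the carbon-bearing compound 1 gave the lower number in a 2.5-fold higher number from compound 1 to compound 3 (0.39 log units; beyond the scatter), compound 4 is expected to move down by about a 5.3-fold lower number from compound 3 to compound 4 (0.73 log units; beyond the scatter). The estimate for compound 4 in this assay is 6000 nM, between 1500 nM and 25000 nM.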

Compound 4, half-maximal inhibitory concentration: 4900 nM
The estimate for compound 4 lay 1.2-fold (0.09 log units) above the measured number; low and high end bracket the measured number.
By their numbers in this assay, from the lowest: compound 4; then compounds 1, 2 and 3 (each within the scatter of the next, the first and the last beyond it).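

In this assay, thiophen-3-yl on this aromatic carbon gives a clear gain over hydroxy (a 6.5-fold lower number from compound 3 to compound 4 (0.81 log units; beyond the scatter)), and the gain also holds against fluoro (a 3.9-fold lower number from compound 2 to compound 4 (0.59 log units; beyond the scatter)) and ethyl (a 2.7-fold lower number from compound 1 to compound 4 (0.42 log units; beyond the scatter)). Among these compounds, the position therefore accepts an aromatic ring, a type of group absent there in the earlier compounds. Compound 4 now has the lowest number of the four, with all three steps beyond the scatter.

On these data alone, whether a phenyl ring, a thiophen-2-yl group or an amine on the same carbon would match this remains open. Nothing shown accounts for the gain.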